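Notes on the step to compound 3

The source may hold more compounds than are shown below. What is called first, only, known or untested is meant among the compounds shown, and "the series" means these compounds.

Compound 2 (`O=C(C1COCCN1)N1CCC2(CCN(c3nccc(NCc4ccc(Cl)cc4Cl)n3)CC2)C1`) gives 233 ug/mL in a physicochemical assay for solubility, read by chemiluminescence, measured as kinetic solubility (on this read-out higher numbers stand for higher solubility and lower numbers for lower solubility), and stands within the scatter of compound 1 (`O=C([C@H]1CCCN1)N1CCC2(CCN(c3nccc(NCc4ccc(Cl)cc4Cl)n3)CC2)C1`) at 180 ug/mL on the same read-out. Compound 3 (`Clc1ccc(CNc2ccnc(N3CCC4(CCN(C[C@H]5CCCN5)C4)CC3)n2)c(Cl)c1`) follows with (pyrrolidin-2-yl)methyl in place of (morpholin-3-yl)carbonyl on an amine nitrogen in a ring as its change. Among the compounds with values here, the one measured step (a 1.3-fold higher number from compound 1 to compound 2 (0.11 log units; within the scatter)) put morpholin-3-yl in place of pyrrolidin-2-yl on a carbonyl carbon and stayed within the scatter. Within the data shown here, no measured pair shows the carbonyl leaving, so this evidence is thin. No step beyond the scatter is expected in this assay (a 1.0-fold lower number from compound 2 to compound 3 (0.01 log units; within the scatter)) for now. For compound 3 the estimate is 230 ug/mL with an expected range from 110 ug/mL to 420 ug/mL as a working figure.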

Compound 3, solubility: 16 ug/mL
For compound 3 the middle estimate is 14-fold (1.16 log units) above the measured one; measured number outside the range, below it.
By their numbers in this assay, from the lowest: compound 3; then compounds 1 and 2 (each within the scatter of the next).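

Within the data shown here, on an amine nitrogen in a ring, this assay shows the first step beyond the scatter: (pyrrolidin-2-yl)methyl in place of (morpholin-3-yl)carbonyl gives a 15-fold lower number from compound 2 to compound 3 (1.16 log units; beyond the scatter) on this core. With the pyrrolidin-2-yl kept and only the carbonyl gone, the result is similar, an 11-fold lower number from compound 1 to compound 3 (1.05 log units; beyond the scatter), so here the large step goes with the loss of the carbonyl and not with the ring exchanged. Nothing measured here explains the step.

Still open, from the compounds shown here alone, is whether a (morpholin-3-yl)methyl group would follow compound 3 or the carbonyl compounds. Going by these compounds, the effect of a sulfonyl link or a longer chain on this nitrogen is also open.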